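The source may hold more compounds than are shown below. What is called first, only, known or untested is meant among the compounds shown, and "the series" means these compounds.

Measured compounds:
Compound 1, `Cn1c(SCC(=O)N2CCC[C@H]2C(=O)Nc2ccccc2-n2cccc2)nc2ccccc21`: 0.3 nM
Compound 2, `O=C(Nc1ccccc1-n1cccc1)[C@@H]1CCCN1C(=O)CSc1nc2ccccc2s1`: 2 nM

In an assay on CHO cells for displacement of a labelled ligand from Orexin receptor type 2 (Homo sapiens) (on this read-out higher numbers stand for weaker inhibition and lower numbers for stronger inhibition), compound 2 gives 2 nM, the highest of the two numbers, with compound 1 at 0.3 nM. Compound 3 is `Cc1ccc2c(c1)nc(SCC(=O)N1CCC[C@H]1C(=O)Nc1ccccc1-n1cccc1)n2C`, which differs from compound 2 by 1,5-dimethyl-1H-benzimidazol-2-yl in place of 1,3-benzothiazol-2-yl on a sulfur. Within the data shown here, the one measured step that bears on this, a 6.7-fold higher number from compound 1 to compound 2 (0.82 log units; beyond the scatter), runs in the opposite direction: it replaced the benzimidazole with the benzothiazole and raised the number. Restoring a benzimidazole, now carrying a second methyl group, is therefore expected to lower the number again; the added methyl has no measured precedent, so its contribution is uncertain. Compound 3 is expected to show a 5.0-fold lower number from compound 2 to compound 3 (0.70 log units; beyond the scatter), with an estimate of 0.4 nM (0.1 nM to 1.5 nM).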

Compound 3, inhibition constant: 0.09 nM
The estimate for compound 3 lay 4.4-fold (0.65 log units) above the measured number; the measured number lies below the stated range.
By their numbers in this assay, from the lowest: compound 3; then compound 1; then compound 2.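

A single methyl in place of hydrogen on an aromatic carbon gives a 3.3-fold lower number from compound 1 to compound 3 (0.52 log units; beyond the scatter) and so shows that this part of the group attached to the sulfur still responds to a small addition. The full change from 1,3-benzothiazol-2-yl to 1,5-dimethyl-1H-benzimidazol-2-yl gives a 22-fold lower number from compound 2 to compound 3 (1.35 log units; beyond the scatter) and leaves compound 3 with the lowest number of the three. Nothing measured here explains either step.

As far as these compounds go, whether chlorine, a methoxy group or a longer chain such as ethyl on that aromatic carbon would lower the number further remains open.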